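Nitro substitution on the pendant phenyl of compound 2

A few compounds are considered here, and "the series" means these few. Any claim that something is new, unique, unknown or untested is made for them only; others in the source may bear on it.

Three compounds of the series have numbers in a functional assay on HCT-116 cells (Homo sapiens) for inhibition, read by sulforhodamine B assay, with a stated time of 72 h; on this read-out higher numbers stand for weaker inhibition and lower numbers for stronger inhibition. Compound 1 `COc1ccc2cc(C(C)c3nnc4n3N=C(c3ccc(Cl)cc3Cl)CS4)ccc2c1` gives 14000 nM, compound 2 `CC(c1ccc(-c2ccccc2)c(F)c1)c1nnc2n1N=C(c1ccccc1)CS2` gives 9700 nM, and compound 3 `CC(C)Cc1ccc(C(C)c2nnc3n2N=C(c2ccc(C(F)(F)F)cc2)CS3)cc1` gives 6500 nM. Compound 2 stands second highest of the three numbers; its gap to compound 1 and its gap to compound 3 both lie within the scatter, so no order among the three can be read from these values. Among the compounds with values here, none of the three pairs differs in only one place, so no measured step is available.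

Compound 4 `CC(c1ccc(-c2ccccc2)c(F)c1)c1nnc2n1N=C(c1ccc([N+](=O)[O-])cc1)CS2` differs from compound 2 by nitro in place of hydrogen on an aromatic carbon. Within the data shown here, no measured pair in this assay shows what this change does; compound 3 carries a trifluoromethyl at the corresponding place but differs elsewhere as well, and its value only shows the same range as compound 2.

The expectation is a step from compound 2 to compound 4 of a 1.3-fold lower number from compound 2 to compound 4 (0.11 log units; within the scatter), that is, no change beyond the scatter. For compound 4 a value of 7500 nM is estimated, with a range of 3000 nM to 20000 nM.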

Compound 4, half-maximal inhibitory concentration: 7100 nM
Beside the measured number, compound 4's estimate is 1.1-fold (0.02 log units) above it; the measured number falls inside the stated range.
By their numbers in this assay, from the lowest: compounds 3, 4, 2 and 1 (each within the scatter of the next, the first and the last beyond it).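

In this assay, within the data shown here, the change from phenyl to 4-nitrophenyl now has a measured size, a 1.4-fold lower number from compound 2 to compound 4 (0.14 log units; within the scatter) and this is the first reading at this position with the rest of the molecule held constant. Nitro in place of hydrogen on this aromatic carbon, para to a large group, therefore leaves the number inside the scatter in this one pair, which the trifluoromethyl of compound 3 could not show, as that compound differs elsewhere as well. No measurement of any property of these compounds bears on this result.

A single pair leaves open whether the same step would hold on the different remainder of compound 1 or compound 3. It also leaves open whether an amine or a carboxylic acid at this place would move the number beyond the scatter.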